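A Hydroxylated Ring Returns to the Aromatic Nitrogen

The source may hold more compounds than are shown below. What is called first, only, known or untested is meant among the compounds shown, and "the series" means these compounds.

Compound 3 `O=C1c2c[n+]([O-])c3ccccc3c2C(=O)c2c1c1ccccc1n2Cc1cn(CC(O)CO)nn1` carries a 2,3-dihydroxypropyl group on an aromatic nitrogen. In a functional assay on SH-SY5Y cells (Homo sapiens) for cytotoxicity, read by MTT assay, with a stated time of 72 h (on this read-out higher numbers stand for weaker inhibition and lower numbers for stronger inhibition), compound 3 gives only a limit, > 1000 nM, so no number stands for it. Compound 2 `O=C1c2c[n+]([O-])c3ccccc3c2C(=O)c2c1c1ccccc1n2Cc1cn(C[C@@H](O)CO)nn1` is drawn with the same atoms and bonds, differing only in the stereocentre described by the fact that one of compounds 2 and 3 is drawn with a defined configuration and the other without, at the place where they differ; in this assay compound 2 gives a limit as well, > 500 nM. The step that the two limits leave unreadable from compound 2 to compound 3 is therefore unreadable. Compound 1 `O=C1c2c[n+]([O-])c3ccccc3c2C(=O)c2c1c1ccccc1n2Cc1cn([C@H]2C[C@H](O)[C@@H](CO)O2)nn1` bears a 4-hydroxy-5-(hydroxymethyl)oxolan-2-yl group on that nitrogen, and in this assay compound 1 gives 620 nM. The step of an at least 1.6-fold higher number from compound 1 to compound 3 (0.20 log units; that floor lies within the scatter) is readable only as a floor, and the step that the limit leaves unreadable from compound 1 to compound 2 is not readable at all.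

Among the compounds with values here, compound 4 `O=C1c2c[n+]([O-])c3ccccc3c2C(=O)c2c1c1ccccc1n2Cc1cn([C@@H]2C[C@H](O)[C@@H](CO)O2)nn1` differs from compound 3 by 4-hydroxy-5-(hydroxymethyl)oxolan-2-yl in place of 2,3-dihydroxypropyl on an aromatic nitrogen, a ring of the same name as the one borne by compound 1. Within the data shown here, the only step that bears on this change is the one from compound 1 to compound 3, run in reverse; its floor sits within the scatter, so a lower number is expected for compound 4, but its size is uncertain, and the step of an at least 1.4-fold lower number from compound 3 to compound 4 (0.15 log units; that floor lies within the scatter) is an estimate. Compound 4 is expected at 700 nM, with a range from 250 nM to 3000 nM.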

Compound 4, half-maximal inhibitory concentration: 150 nM
The estimate for compound 4 lay 4.7-fold (0.67 log units) above the measured number, and the stated range ends above it.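

In this assay, the hydroxylated ring now separates clearly from the open chain: the change gives an at least 6.6-fold lower number from compound 3 to compound 4 (0.82 log units; beyond the scatter), and against the chain with a drawn configuration it gives an at least 3.3-fold lower number from compound 2 to compound 4 (0.52 log units; beyond the scatter), two floors that lie beyond the scatter, whereas the earlier floor for this change lay within it. Within the data shown here, the ring's configuration matters as well, for the step of a 4.1-fold lower number from compound 1 to compound 4 (0.62 log units; beyond the scatter) comes with no change of atoms or bonds, only one saturated ring carbon drawn R in the first compound and S in the second. This step can be set on that single ring carbon alone: the fact that compounds 1 and 4 differ only in the configuration as drawn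

The compounds shown leave open what the other two stereocentres of the ring contribute, and the steps that rest on the limits of the chain compounds alone cannot be read, so the effect of the chain's own configuration stays unknown. They also do not tell how an amine or a carboxylic acid in place of a ring hydroxyl group, or a longer chain on this aromatic nitrogen, would read in this assay.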